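Urea series: iodo for methoxy on the aryl ring

This account rests on a few compounds, and the source may have more. Where it says the series, first, only, none or still open, it means among the compounds named here.

Compound 1 `Cc1ccccc1NC(=O)N[C@H](C)c1ccccc1` and compound 2 `COc1ccccc1NC(=O)N[C@H](C)c1ccccc1` share one urea core and differ only by methoxy in place of methyl on an aromatic carbon. In an ADME assay on the whole organism with Oryza sativa as the target, tested at 0.1 uM (a lower number here means a stronger effect, a higher number a weaker effect of the compound at the concentration tested), compound 1 gives 100%, and in this assay compound 2 gives 100%. The step of no change at the digits printed from compound 1 to compound 2 (within the scatter) shows that this exchange left the read-out where it was. Compound 2 therefore stands level with compound 1 at the digits shown, with no change beyond the scatter.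

Compound 3 `C[C@@H](NC(=O)Nc1ccccc1I)c1ccccc1` is not yet measured. It differs from compound 2 as follows: iodo in place of methoxy on an aromatic carbon. Among the measured compounds shown here, only the step from compound 1 to compound 2 bears on this change, and that step was flat; it concerns a different group entering at the same aromatic carbon, so it gives no direction for iodo. With nothing in the measured pairs pointing away from the present level, no step beyond the scatter is expected in this assay, with a number 3 percentage points lower from compound 2 to compound 3 (within the scatter) as the expected shift. Compound 3 is estimated at 97%, with a range from 82% to 100%.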

Compound 3, a percentage reported as activity, at one concentration (the size of the read-out at that concentration, not a potency): 100%
Compound 3: middle estimate off by 3 percentage points, on the low side; the range from low to high includes it.
By their numbers in this assay, from the lowest: compounds 1, 2 and 3 (each within the scatter of the next).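

In this assay, iodo in place of methoxy on an aromatic carbon gives no change at the digits printed from compound 2 to compound 3 (within the scatter), and iodo in place of methyl at that same carbon gives no change at the digits printed from compound 1 to compound 3 (within the scatter). This place, on an aromatic carbon of a six-membered aromatic ring of carbon only and ortho to a large group, has now carried methyl, methoxy and iodo without any separation in the read-out, and the exchange of methoxy, with its hydrogen-bond acceptor, for iodo, with none, leaves the reading in the same place as the earlier exchange of methyl for methoxy did. No supporting evidence bears on this flat result.

The compounds shown leave open whether any group at this carbon can move the read-out in this assay, for example an amine, a carboxylic acid or a longer chain, since all three groups so far read alike at the single concentration tested. They also leave open whether a change elsewhere on the shared core, such as a substituent on the other aromatic ring or a replacement of the urea hydrogen by a methyl group, would separate compounds where these exchanges do not.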